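This account rests on a few compounds, and the source may have more. Where it says the series, first, only, none or still open, it means among the compounds named here.

Measured so far in a functional assay on KYSE-450 cells (Homo sapiens) for inhibition, read by MTT assay, with a stated time of 48 h; a lower number here means a stronger inhibitor, a higher number a weaker inhibitor:
Compound 1 `COc1cc(NCc2ccccc2)cc(OC)c1OC` gives > 80000 nM, which is a limit of the assay rather than a number.
Compound 2 `COc1cc(NCc2ccc(Cl)cc2)cc(OC)c1OC` gives > 80000 nM, again a limit of the assay.
Compound 3 `CC/C=C/C(=O)N(Cc1ccc(OC)c(O)c1)c1cc(OC)c(OC)c(OC)c1` gives 72 nM.

Among the compounds with values here, compound 3 therefore holds the only real number among the three; the other two sit at the limit of > 80000 nM in this assay, at which 2 of the 3 values shown sit. Within the data shown here, the single measured step, a step that the two limits leave unreadable from compound 1 to compound 2, cannot be read, so no measured step tells how a change at the carbonyl carbon of compound 3 will play out. Compound 4 `COc1ccc(CN(C(=O)CBr)c2cc(OC)c(OC)c(OC)c2)cc1O` differs from compound 3 by bromomethyl in place of but-1-en-1-yl on a carbonyl carbon. The but-1-en-1-yl chain leaves and a bromomethyl takes its place, while the rest of the molecule stays as it is in compound 3. Among the measured compounds shown here, with no measured step to lean on, the estimate for compound 4 is 100 nM, with a range from 20 nM to 500 nM. The estimated step of a 1.4-fold higher number from compound 3 to compound 4 (0.14 log units; within the scatter) is expected to be small, with the range wide enough to allow a real change in either direction.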

Compound 4, half-maximal inhibitory concentration: 120 nM
Compound 4: middle estimate off by 1.2-fold (0.08 log units), on the low side, and the stated range covers the measured number.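

In this assay, within the data shown here, this is the first step that can be read, and it gives a 1.7-fold higher number from compound 3 to compound 4 (0.22 log units; within the scatter). At this place on the carbonyl carbon, then, the but-1-en-1-yl chain and the smaller bromomethyl group cannot be told apart, and the double bond of the chain is not needed for a value of this size in this one pair. Among these compounds, nothing measured here explains why the two groups match, so this shows only that the change is tolerated, not how.

Still open, going by these compounds, is whether other groups on this carbonyl carbon, such as an amine, a carboxylic acid or a longer chain, would also leave the value in this range. Also open, on these data alone, is whether the bromine itself matters, which a comparison with plain methyl or chloromethyl at the same place could show.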